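Swapping a saturated ring for an aromatic one

The source may report more compounds than this note shows. Statements on the series, on what has been measured and on what is new or still open speak of the compounds shown alone.

Measured compounds:
- compound 1, `Cc1cnc(N2CCN(NC(=S)Nc3cccnc3)CC2)c(Cl)c1`: > 50000 nM
- compound 2, `S=C(Nc1cccnc1)NC1CCN(c2cc(OC3CCCCC3)ccn2)CC1`: 3400 nM
- compound 3, `FC(F)(F)Oc1ccc(Oc2ccnc(N3CCC[C@@H](NC(=S)Nc4cccnc4)C3)c2Cl)c(Cl)c1`: 100000 nM

Three thiourea compounds have been tested in an assay on membranes from brain for binding affinity to Lysophosphatidylserine lipase ABHD12 (Mus musculus), read by fluorescence, with a stated time of 20 min; a lower number here means a stronger inhibitor, a higher number a weaker inhibitor. Compound 1 reaches only the limit of the assay, at > 50000 nM, so no number is available for it; this is described by the limit of > 50000 nM in this assay, at which 1 of the 3 values shown sits. Compound 3 gives 100000 nM. Compound 2 holds the lowest number of the two measured values, at 3400 nM, and the gap to compound 3 lies beyond the scatter of this assay.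

The next compound to be examined is compound 4, `COc1ccc(Oc2ccnc(N3CCC(NC(=S)Nc4cccnc4)CC3)c2)cc1`. It differs from compound 2 in one place: 4-methoxyphenyl in place of cyclohexyl on an oxygen on an aromatic ring. Compound 3 also carries an aromatic ring on this oxygen, but it differs from compound 4 in several further places, so it gives no direct reading of the change.

Among the compounds with values here, since no single-point step between measured compounds exists, the size and direction of the change must be guessed. The step from compound 2 to compound 4 in this assay is expected to be modest, a 1.7-fold lower number from compound 2 to compound 4 (0.23 log units; within the scatter), with a wide range around it. Compound 4 is estimated to give 2000 nM, between 300 nM and 15000 nM.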

Compound 4, half-maximal inhibitory concentration: 2900 nM
Compound 4: the middle estimate sits 1.5-fold (0.16 log units) below what was measured; the range from low to high includes it.
By their numbers in this assay, from the lowest: compounds 4 and 2 (each within the scatter of the next); then compound 3.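

In this assay, the exchange of cyclohexyl for 4-methoxyphenyl on an oxygen on an aromatic ring gives a 1.2-fold lower number from compound 2 to compound 4 (0.07 log units; within the scatter), so the two compounds cannot be told apart. Within the data shown here, this is the first direct reading at this position, which the earlier compounds could not give, since none of them differed from another in one place only. A six-membered non-aromatic ring of carbon and a six-membered aromatic ring carrying a methoxy group, with its added hydrogen-bond acceptor, can therefore stand on this oxygen with no difference beyond the scatter, and compound 4 gives 2900 nM in the same range as compound 2.

The aromatic ring and the methoxy group enter together, so the compounds shown leave open what an unsubstituted phenyl, or a carboxylic acid or an amine in place of the methoxy group, would give at this position. No measurement shown here bears on why cyclohexyl and 4-methoxyphenyl give such similar numbers.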